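The source may report more compounds than this note shows. Statements on the series, on what has been measured and on what is new or still open speak of the compounds shown alone.

Measured compounds, with their numbers in a functional assay on HT-29 cells (Homo sapiens) for cytotoxicity, read by MTT assay, with a stated time of 72 h; a higher number here means a weaker inhibitor, a lower number a stronger inhibitor:

Compound 1, `COc1cc2c(Oc3ccc(NC(=O)c4cc(-c5ccccc5)ccn4)cc3F)ccnc2cc1OCCCN1CCN(C)CC1`, gives 82 nM.
Compound 2, `COc1cc2c(Oc3ccc(NC(=O)c4cc(-c5ccc(F)cc5)ccn4)cc3F)ccnc2cc1OCCCN1CCCCC1`, gives 1370 nM.
Compound 3, `COc1cc2c(Oc3ccc(NC(=O)c4cc(-c5ccccc5F)ccn4)cc3F)ccnc2cc1OCCCN1CCCCC1`, gives 320 nM.

Among these three, compound 3 stands second highest in this assay: compound 1 sits lower, compound 2 sits higher, and both gaps are beyond the scatter. Going by the values given here, the only single-point change measured so far is a 4.3-fold lower number from compound 2 to compound 3 (0.63 log units; beyond the scatter), a modest step that goes with exchanging 4-fluorophenyl for 2-fluorophenyl on the aromatic carbon of the shared core. Among the compounds with values here, compound 1, which carries an unsubstituted phenyl at that carbon, differs from compound 3 in two places and therefore offers no clean step.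

Compound 4, `COc1cc2c(Oc3ccc(NC(=O)c4cc(-c5ccc(C(F)(F)F)cc5)ccn4)cc3F)ccnc2cc1OCCCN1CCCCC1`, has not yet been measured. It differs from compound 3 by 4-(trifluoromethyl)phenyl in place of 2-fluorophenyl on an aromatic carbon. This change runs in the opposite sense to the measured step, returning the substituent to the same ring position as in compound 2 while enlarging it to trifluoromethyl. On that basis the number for compound 4 is expected to rise beyond the scatter, with a 3.8-fold higher number from compound 3 to compound 4 (0.57 log units; beyond the scatter) as the estimated step, landing near compound 2. The estimate for compound 4 in this assay is 1200 nM, within a range from 400 nM to 3600 nM.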

Compound 4, half-maximal inhibitory concentration: 230 nM
Compound 4: the middle estimate sits 5.2-fold (0.72 log units) above what was measured, and the stated range ends above it.
By their numbers in this assay, from the lowest: compound 1; then compounds 4 and 3 (each within the scatter of the next); then compound 2.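

Working from this assay, the measured step from fluoro to trifluoromethyl at the same ring position, a 6.0-fold lower number from compound 2 to compound 4 (0.77 log units; beyond the scatter), shows that a substituent there does not by itself go with the high number of compound 2. The exchange of 2-fluorophenyl for the larger 4-(trifluoromethyl)phenyl, a 1.4-fold lower number from compound 3 to compound 4 (0.14 log units; within the scatter), leaves those two groups unseparated in this assay, so the earlier step from 4-fluorophenyl to 2-fluorophenyl cannot be read as a general preference for substitution at one ring position of the phenyl. Among compounds 2, 3 and 4, which share the same side chain, only compound 2 stands apart, and the entering group's greater heavy-atom count does not go with a higher number at this position opposite the ring nitrogen.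

No measurement of any other kind is available to account for the difference between the fluoro and trifluoromethyl compounds.
Still open, on these data alone, is whether a methoxy or nitrile group in place of the trifluoromethyl of compound 4 would group with compound 2 or with compound 4, and how the unsubstituted phenyl of compound 1 would read on the side chain shared by compounds 2, 3 and 4.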